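A dinitrophenyl variant of two analogues at the assay limit

The compounds below may be only part of what the source reports. "The series", "measured", "known", "first", "only" and "open" are said of these compounds alone.

Compound 1 `N#CC1=C(N)Oc2c(N)cc3nc4ccccc4nc3c2C12C(=O)N(Cc1cnnn1-c1cccc(Br)c1)c1ccccc12` and compound 2 `Cc1cc(C)cc(-n2nncc2CN2C(=O)C3(C(C#N)=C(N)Oc4c(N)cc5nc6ccccc6nc5c43)c3ccccc32)c1` are the two measured compounds. In an ADME assay on L02 cells (Homo sapiens) for antiproliferative activity, read by MTT assay, with a stated time of 48 h (on this read-out higher numbers stand for weaker inhibition and lower numbers for stronger inhibition), compound 1 gives > 50000 nM, which is a limit of the assay and not a number. In this assay compound 2 gives > 50000 nM, likewise a limit. The step that the two limits leave unreadable from compound 1 to compound 2 cannot be read because of the limit of > 50000 nM in this assay, at which 2 of the 2 values shown sit. Compound 3 `N#CC1=C(N)Oc2c(N)cc3nc4ccccc4nc3c2C12C(=O)N(Cc1cnnn1-c1ccc([N+](=O)[O-])cc1[N+](=O)[O-])c1ccccc12` has not yet been measured; it differs from compound 2 by 2,4-dinitrophenyl in place of 3,5-dimethylphenyl on an aromatic nitrogen. Among the measured compounds shown here, no measured step covers a 2,4-dinitrophenyl, and compound 2 stands at the limit. The step of a number no higher from compound 2 to compound 3 (the limit leaves the size open) is expected to stay within the scatter, so compound 3 is estimated at 50000 nM in this assay, between 20000 nM and 120000 nM.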

Compound 3, half-maximal inhibitory concentration: 22800 nM
The estimate for compound 3 lay 2.2-fold (0.34 log units) above the measured number; measured number inside the range.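

On the aromatic nitrogen of the five-membered ring, the substituent can shift the read-out in this assay: 2,4-dinitrophenyl gives an at least 2.1-fold lower number from compound 2 to compound 3 (0.34 log units; beyond the scatter), and an at least 2.1-fold lower number from compound 1 to compound 3 (0.34 log units; beyond the scatter). The step between compound 1 and compound 2 cannot be read, so the earlier pair could not show this. The true sizes of the two new steps also stay open because the comparison starts from a limit: the limit of > 50000 nM in this assay, at which 2 of the 3 values shown sit.

The compounds shown leave open whether one nitro group would be enough, or whether both are needed. They also leave open how an amine or a carboxylic acid on this phenyl ring would read.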